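The compounds below may be only part of what the source reports. "The series", "measured", "known", "first", "only" and "open" are said of these compounds alone.

Measured compounds:
Compound 1 `CC(C)C(O)(c1cccc(-c2ccc(F)cc2)c1)c1c[nH]cn1` in an assay on microsomes from Testis (strain Sprague-Dawley) for inhibition of steroid 17-alpha-hydroxylase/17,20 lyase (Rattus norvegicus); a lower number here means a stronger inhibitor, a higher number a weaker inhibitor: 8.3 nM
Compound 2 `CC(=O)Nc1cccc(-c2ccc(C(O)(c3c[nH]cn3)C(C)C)cc2)c1` in this assay: 17 nM

Compound 2 has the higher of the two numbers in this assay; its nearest neighbour is compound 1, whose number is lower by an amount beyond the usual scatter. Compound 3, `CC(=O)Nc1cccc(-c2ccc([C@@](O)(c3c[nH]cn3)C(C)C)cc2)c1`, differs from compound 2 as follows: the two compounds have the same atoms and bonds; at least one stereo element is drawn with a configuration in one of them and without one in the other: 1 of 1 stereo elements differ; a stereocentre at a saturated chain carbon is drawn without a configuration in compound 2 and R in compound 3. Compound 3 is thus a single enantiomer drawn out of the unresolved compound 2. Among the compounds with values here, no step between measured compounds matches this kind of change, so nothing measured here shows how far a single enantiomer departs from the unresolved material. Compound 3 is expected to give a number near that of compound 2, with the step of a 1.4-fold lower number from compound 2 to compound 3 (0.15 log units; within the scatter) expected to stay within the scatter, though a larger move in either direction cannot be ruled out. The estimate for compound 3 in this assay is 12 nM, within a range from 4 nM to 60 nM.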

Compound 3, half-maximal inhibitory concentration: 770 nM
Compound 3: the middle estimate sits 64-fold (1.81 log units) below what was measured; the whole stated range lies below it.
By their numbers in this assay, from the lowest: compound 1; then compound 2; then compound 3.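

Until now, compounds 1 and 2 were both drawn without a configuration, so they said nothing about whether the stereocentre at a saturated chain carbon matters. Setting it as R brings a 45-fold higher number from compound 2 to compound 3 (1.66 log units; beyond the scatter) in this assay, so the configuration at this position has a large effect on the number, and the R form cannot account for the much lower number of the unresolved compound 2. The atoms and bonds are unchanged, so the step can be tied to only one difference: the fact that one of compounds 2 and 3 is drawn with a defined configuration and the other without, at the place where they differ

From the compounds shown here alone, what the opposite enantiomer gives in this assay stays open, as does how much of the number of compound 2 it accounts for. Going by these compounds, it is also open whether the same dependence on configuration would hold with a cyclopropyl group or a longer chain at this stereocentre.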